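The source may report more compounds than this note shows. Statements on the series, on what has been measured and on what is new or still open speak of the compounds shown alone.

Of the compounds shown here, two of a shared core have been measured so far. Compound 1 `CCOC(=O)c1c(CSc2nccn2C)nc2cc(OC)c(OC)cc2c1-c1ccc(OC)c(OC)c1` gives 60% in a functional assay on the whole organism for inhibition, with Rattus norvegicus as the target, at a dose of 50 mg/kg by the oral route; a higher number here means more inhibition at the dose given (going by the name of the read-out), a lower number less inhibition. Compound 2 `CCOC(=O)c1c(CSc2nncn2C)nc2cc(OC)c(OC)cc2c1-c1ccc(OC)c(OC)c1` gives 66% in this assay; the two numbers sit within the scatter of each other, the step being a number 6 percentage points higher from compound 1 to compound 2 (within the scatter), so neither compound can be said to inhibit more than the other.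

Compound 3 `CCOC(=O)c1c(CSc2ncc[nH]2)nc2cc(OC)c(OC)cc2c1-c1ccc(OC)c(OC)c1` is not yet measured. It differs from compound 2 in one place: 1H-imidazol-2-yl in place of 4-methyl-4H-1,2,4-triazol-3-yl on a sulfur. Among the compounds with values here, the only measured step that bears on this, the exchange of one five-membered ring on the same sulfur from compound 1 to compound 2, was a number 6 percentage points higher from compound 1 to compound 2 (within the scatter), within the scatter. A further exchange at that position is therefore expected to move the number little; the estimated step is a number 6 percentage points lower from compound 2 to compound 3 (within the scatter), none beyond the scatter. Compound 3 is expected to give about 60%, within a range of 40% to 78%.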

Compound 3, a percentage reported as inhibition, in the whole organism at one dose (the size of the read-out at that dose, not a potency): 60%
For compound 3 middle estimate and measured number coincide at the digits printed; low and high end bracket the measured number.
By their numbers in this assay, from the lowest: compounds 1, 3 and 2 (each within the scatter of the next).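

In this assay, taking the methyl off the aromatic nitrogen of the 1-methyl-1H-imidazol-2-yl group gives no change at the digits printed from compound 1 to compound 3 (within the scatter), and placing 1H-imidazol-2-yl on the sulfur instead of 4-methyl-4H-1,2,4-triazol-3-yl gives a number 6 percentage points lower from compound 2 to compound 3 (within the scatter). This position therefore accepts a five-membered aromatic ring with a hydrogen on its nitrogen as well as one with a methyl there, and this assay does not tell the three compounds apart. No measurement is available that would explain why these groups read alike.

From the compounds shown here alone, all three compounds carry a five-membered aromatic ring on the sulfur, so the effect of something quite different there, such as an amine, a carboxylic acid or a plain ethyl chain, remains open. Going by these compounds, whether the sulfur itself matters, compared with an oxygen in its place, also remains open.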